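Replacing the amide substituent of compound 3

The compounds below may be only part of what the source reports. "The series", "measured", "known", "first", "only" and "open" are said of these compounds alone.

Measured in a functional assay on MCF7 cells (Homo sapiens) for antiproliferative activity, read by MTT assay, with a stated time of 24 h; on this read-out higher numbers stand for weaker inhibition and lower numbers for stronger inhibition:
Compound 1 `CCn1c(C(=O)NCC(=O)OC)ccc1C(CC)(CC)c1ccc(OCS(=O)(=O)c2ccccc2)c(C)c1`: > 50000 nM (a limit)
Compound 2 `CCn1c(C(=O)N[C@@H](CO)CCO)ccc1C(CC)(CC)c1ccc(OCS(=O)(=O)c2ccccc2)c(C)c1`: 27400 nM
Compound 3 `CCn1c(C(=O)N[C@@H](CO)CCCO)ccc1C(CC)(CC)c1ccc(OCS(=O)(=O)c2ccccc2)c(C)c1`: 29600 nM

In this assay compound 3 gives 29600 nM, within the scatter of compound 2 at 27400 nM. The measured step is a 1.1-fold higher number from compound 2 to compound 3 (0.03 log units; within the scatter).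

The value of compound 1, > 50000 nM, is a limit and not a number.

Compound 4 `CCn1c(C(=O)NC2(C(=O)O)CC2)ccc1C(CC)(CC)c1ccc(OCS(=O)(=O)c2ccccc2)c(C)c1` carries its change on the amide-type nitrogen: a group of 6 heavy atoms (4 carbon, 2 oxygen; one three-membered non-aromatic ring of carbon only) in place of a group of 7 heavy atoms (5 carbon, 2 oxygen; no ring), on an amide-type nitrogen. Within the data shown here, none of the measured compounds bears the 1-carboxycyclopropyl group, so the evidence is indirect. Among the measured compounds shown here, three steps concern the same nitrogen: an at least 1.8-fold lower number from compound 1 to compound 2 (0.26 log units; that floor lies within the scatter), an at least 1.6-fold lower number from compound 1 to compound 3 (0.22 log units; that floor lies within the scatter) and a 1.1-fold higher number from compound 2 to compound 3 (0.03 log units; within the scatter). The first two are only floors, and all three lie within the scatter as far as they are shown. No step beyond the scatter is therefore expected, and no direction is favoured, although the uncertainty is wide. The expected step is a 1.1-fold higher number from compound 3 to compound 4 (0.03 log units; within the scatter). For compound 4 the estimate is 32000 nM, with an expected range of 14000 nM to 70000 nM.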

Compound 4, half-maximal inhibitory concentration: 41200 nM
Estimate against measurement, compound 4: 1.3-fold (0.11 log units) below; the range from low to high includes it.
By their numbers in this assay, from the lowest: compounds 2, 3 and 4 (each within the scatter of the next). At a limit, above all of these: compound 1.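

In this assay, among these compounds, the 1-carboxycyclopropyl group puts a ring on the amide-type nitrogen for the first time in this set, yet the number stays within the scatter of both hydroxylated chains: a 1.4-fold higher number from compound 3 to compound 4 (0.14 log units; within the scatter) and a 1.5-fold higher number from compound 2 to compound 4 (0.18 log units; within the scatter). Against the methoxycarbonylmethyl compound only a floor can be read, an at least 1.2-fold lower number from compound 1 to compound 4 (0.08 log units; that floor lies within the scatter). Compound 1 remains a limit and not a number, so its distance from the others stays unknown: the limit of > 50000 nM in this assay, at which 1 of the 4 values shown sits.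

The ring and the carboxylic acid enter together in compound 4, so their separate contributions remain unresolved. As far as these compounds go, whether an amine, a longer chain or a larger carbon ring on this nitrogen would move the number beyond the scatter also stays open.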